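The source may hold more compounds than are shown below. What is called first, only, known or untested is meant among the compounds shown, and "the series" means these compounds.

Measured so far:
compound 1 `O=S(=O)(c1cc(Cl)cc(Cl)c1)c1cnc2c(F)cccc2c1-c1ccccc1F` — 0.44 mL/min
compound 2 `Cc1ccc(S(=O)(=O)c2cnc3c(F)cccc3c2-c2ccc(F)cc2)cc1F` — 2.75 mL/min

In an ADME assay on microsomes from liver (Homo sapiens) for metabolic stability, tested at 2.5 uM (on this read-out lower numbers stand for slow clearance and higher numbers for fast clearance), compound 2 stands highest of the two numbers; compound 1 sits well below it, a gap beyond the scatter. Compound 3 `O=S(=O)(c1cc(Cl)cc(Cl)c1)c1cnc2c(F)cccc2c1-c1ccc(F)cc1` is not yet measured. Its change from compound 2 is 3,5-dichlorophenyl in place of 3-fluoro-4-methylphenyl on a sulfonyl sulfur. Going by the values given here, no measured pair shows this exact step, so the size of the move is uncertain; a step downward is expected, since in this assay compound 1 carrying the same 3,5-dichlorophenyl gives 0.44 mL/min. For compound 3 the expected step is a 3.1-fold lower number from compound 2 to compound 3 (0.49 log units; beyond the scatter). Compound 3 is estimated at 0.9 mL/min, between 0.3 mL/min and 2.5 mL/min.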

Compound 3, intrinsic clearance in a liver preparation (reported as CLH), per the amount of preparation that the assay uses: 1.01 mL/min
The estimate for compound 3 lay 1.1-fold (0.05 log units) below the measured number; measured number inside the range.
By their numbers in this assay, from the lowest: compound 1; then compound 3; then compound 2.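

In this assay, the change on a sulfonyl sulfur now has a direct reading: 3,5-dichlorophenyl in place of 3-fluoro-4-methylphenyl gives a 2.7-fold lower number from compound 2 to compound 3 (0.44 log units; beyond the scatter) with the rest of the structure unchanged. With the 3,5-dichlorophenyl held fixed, 4-fluorophenyl in place of 2-fluorophenyl on an aromatic carbon gives a 2.3-fold higher number from compound 1 to compound 3 (0.36 log units; beyond the scatter) and so shows that this second site also moves the number. Nothing available here explains either step.

On these data alone, whether an amine or a morpholine on the sulfonyl sulfur would give a lower number remains open.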